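Swapping chloro for phenyl on the anilide of compound 2

The source may report more compounds than this note shows. Statements on the series, on what has been measured and on what is new or still open speak of the compounds shown alone.

Among the compounds with values here, compound 2 `C[C@H](NC(=O)C(=O)Nc1ccccc1Cl)C(=O)N[C@@H](CC(=O)O)C(=O)COC(=O)c1c(Cl)cccc1Cl` is the weaker of the two measured members in a functional assay on Jurkat cells (Homo sapiens) for inhibition (on this read-out higher numbers stand for weaker inhibition and lower numbers for stronger inhibition), where compound 2 gives 1170 nM. Compound 1 `C[C@H](NC(=O)C(=O)Nc1ccccc1-c1ccccc1)C(=O)N[C@@H](CC(=O)O)C(=O)COC(=O)c1c(F)c(F)cc(F)c1F`, which carries a different acyloxymethyl ketone ester, gives 130 nM in this assay, a gap between the two well beyond the scatter, though the two structures differ in two places at once and no single step can be read from them. Compound 3 `C[C@H](NC(=O)C(=O)Nc1ccccc1-c1ccccc1)C(=O)N[C@@H](CC(=O)O)C(=O)COC(=O)c1c(Cl)cccc1Cl` keeps the ester of compound 2 and changes only the anilide: phenyl in place of chloro on an aromatic carbon, the same difference read one bond further out being 2-chlorophenyl to 2-phenylphenyl. Since compound 1 with this phenyl gives 130 nM, compound 3 is expected to show stronger inhibition than compound 2, with a step of a 3.3-fold lower number from compound 2 to compound 3 (0.52 log units; beyond the scatter) estimated, though part of the gap may rest on the ester. Compound 3 is thus estimated at 350 nM, within a range of 120 nM to 1000 nM.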

Compound 3, half-maximal inhibitory concentration: 390 nM
The estimate for compound 3 lay 1.1-fold (0.05 log units) below the measured number; measured number inside the range.
By their numbers in this assay, from the lowest: compound 1; then compound 3; then compound 2.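

In this assay, the step of a 3.0-fold lower number from compound 2 to compound 3 (0.48 log units; beyond the scatter) holds the 2,6-dichlorophenyl ester fixed, so phenyl in place of chloro on this aromatic carbon, ortho to a large group, is tied to stronger inhibition beyond the scatter on its own. Compound 3 also separates the two changes that were mixed in the earlier pair: with the phenyl anilide held fixed, 2,6-dichlorophenyl in place of 2,3,5,6-tetrafluorophenyl on a carbonyl carbon gives a 3.0-fold higher number from compound 1 to compound 3 (0.48 log units; beyond the scatter), so the ester matters as well, and by a step of the same printed size. Nothing at hand explains either step.

On these data alone, whether the phenyl step holds with the 2,3,5,6-tetrafluorophenyl ester remains open. So does how a methyl, a methoxy or a cyclohexyl group would read at this same place, which would show whether an aromatic ring is needed there.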